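The compounds below may be only part of what the source reports. "The series", "measured", "known", "first", "only" and "open" are said of these compounds alone.

Of the compounds shown here, two have so far been measured in an assay for inhibition of Indoleamine 2,3-dioxygenase 1 (Homo sapiens), read by spectrophotometry, with a stated time of 30 min, tested at 10 uM; on this read-out lower numbers stand for less inhibition and higher numbers for more inhibition at the one concentration tested (going by the name of the read-out). Compound 1 `Cc1cc(C(O)Cc2ccccc2)c2cn[nH]c2c1` carries a methyl on an aromatic carbon of the shared core, and in this assay compound 1 gives 76%. Compound 2 `C#Cc1cc(C(O)Cc2ccccc2)c2cn[nH]c2c1` carries an ethynyl in the same place, and in this assay compound 2 gives 32%. Among the compounds with values here, compound 2 therefore stands at the lower of the two numbers, with compound 1 as its only neighbour, and the single measured step is a number 44 percentage points lower from compound 1 to compound 2 (beyond the scatter), a large step that came with the arrival of the ethynyl.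

Compound 3 `CCc1cc(C(O)Cc2ccccc2)c2cn[nH]c2c1` is the next compound to be measured. It differs from compound 2 in one place: ethyl in place of ethynyl on an aromatic carbon. The group whose arrival accompanied the large drop is removed and an ethyl takes its place. Because a number 44 percentage points lower from compound 1 to compound 2 (beyond the scatter) was large, its reversal is expected to recover a good part of what was lost, so the step of a number 33 percentage points higher from compound 2 to compound 3 (beyond the scatter) is expected to be upward and beyond the scatter. Compound 3 is estimated to give 65% in this assay, within a range from 42% to 85%.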

Compound 3, a percentage reported as inhibition, at one concentration (the size of the read-out at that concentration, not a potency): 70%
The estimate for compound 3 lay 5 percentage points below the measured number; the range from low to high includes it.
By their numbers in this assay, from the lowest: compound 2; then compounds 3 and 1 (each within the scatter of the next).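

In this assay, an ethyl in place of the ethynyl of compound 2 gives a number 38 percentage points higher from compound 2 to compound 3 (beyond the scatter) even though the two groups have the same count of heavy atoms, so atom count alone does not separate them at this position, and the triple bond is the listed feature that leaves with the ethynyl. Going from methyl to ethyl at the same aromatic carbon gives a number 6 percentage points lower from compound 1 to compound 3 (within the scatter) and so shows that the two saturated groups cannot be told apart here, leaving the ethynyl as the only one of the three groups tied to a clearly lower number. No measurement at hand bears on the reason for this difference.

A hydrogen, a longer chain such as butyl, a small ring such as cyclopropyl, or an amine at this position could each test whether the picture from these three groups holds more widely. As far as these compounds go, the read-out also gives only the size of inhibition at one concentration, so any difference in potency between the methyl and ethyl compounds remains open.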